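Swapping 3-bromophenyl for 2-fluorophenyl in compound 4

A few compounds are considered here, and "the series" means these few. Any claim that something is new, unique, unknown or untested is made for them only; others in the source may bear on it.

- compound 1 `FC(F)(F)c1cccc(NC(=S)Nc2ccc(Cl)cc2)c1` gives 6800 nM
- compound 2 `FC(F)(F)c1cccc(NC(=S)Nc2ccccc2)c1` gives 39000 nM
- compound 3 `FC(F)(F)c1cccc(NC(=S)Nc2cccc(Br)c2)c1` gives 9200 nM

In an ADME assay on MT4 cells (Homo sapiens) for cytotoxicity (a higher number here means that more compound is tolerated, a lower number that less compound is tolerated), compound 3 gives 9200 nM, which lies within the scatter of compound 1, as a 1.4-fold higher number from compound 1 to compound 3 (0.13 log units; within the scatter) shows. It lies clearly under compound 2, as a 4.2-fold lower number from compound 2 to compound 3 (0.63 log units; beyond the scatter) shows.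

The next molecule is compound 4 `Fc1ccccc1NC(=S)Nc1cccc(C(F)(F)F)c1`, which differs from compound 3 as follows: 2-fluorophenyl in place of 3-bromophenyl on an amide-type nitrogen. In short, 2-fluorophenyl stands in place of 3-bromophenyl on an amide-type nitrogen.

Among the measured compounds shown here, two measured steps bear on this. They are a 5.7-fold higher number from compound 1 to compound 2 (0.76 log units; beyond the scatter) and a 4.2-fold lower number from compound 2 to compound 3 (0.63 log units; beyond the scatter), both modest and beyond the scatter. Among these three compounds, the one without a halogen on that ring has the highest number, and neither halogen-bearing compound goes against this. For the measured compounds named here, compound 4 keeps a halogen, but no measured compound carries fluoro, so the guide is loose. A modest upward move is expected, with little change also possible.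

The expected change is a 2.0-fold higher number from compound 3 to compound 4 (0.29 log units; within the scatter). For compound 4 the estimate is 18000 nM, with an expected range from 7000 nM to 45000 nM.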

Compound 4, half-maximal cytotoxic concentration: 47000 nM
Estimate against measurement, compound 4: 2.6-fold (0.42 log units) below; the whole stated range lies below it.
By their numbers in this assay, from the lowest: compounds 1 and 3 (each within the scatter of the next); then compounds 2 and 4 (each within the scatter of the next).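

In this assay, a halogen on this ring does not by itself bring the number down: a 1.2-fold higher number from compound 2 to compound 4 (0.08 log units; within the scatter), so compound 4 stays level with compound 2, which has no halogen there, unlike the chloro and bromo compounds. The 2-fluorophenyl compound stands clearly apart from those two, with a 5.1-fold higher number from compound 3 to compound 4 (0.71 log units; beyond the scatter) and a 6.9-fold higher number from compound 1 to compound 4 (0.84 log units; beyond the scatter), yet each of these steps changes both the halogen and where it sits, so the two changes cannot be separated. Nothing shown here gives a reason for this difference.

On these data alone, whether the kind of halogen or its place matters more remains open, and a 2-chlorophenyl or 3-fluorophenyl ring would bear on that. As far as these compounds go, how a ring carrying a methoxy group or an amine would behave is also open.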